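A few compounds are considered here, and "the series" means these few. Any claim that something is new, unique, unknown or untested is made for them only; others in the source may bear on it.

Measured so far in a functional assay on RT-112 cells (Homo sapiens) for antiproliferative activity, read by MTT assay, with a stated time of 72 h; on this read-out lower numbers stand for stronger inhibition of growth and higher numbers for weaker inhibition of growth:
- compound 1 `COc1cc(Nc2ncnc3c(NC(=O)Nc4ccc(F)cc4C(F)(F)F)cccc23)cc(OC)c1` gives 2970 nM
- compound 2 `COc1cc(Nc2ncnc3c(NC(=O)Nc4cccc(C)c4C)cccc23)cc(OC)c1` gives 5910 nM
- compound 3 `COc1cc(Nc2ncnc3c(NC(=O)Nc4ccc(Cl)c(Cl)c4)cccc23)cc(OC)c1` gives 6230 nM

Two of these numbers sit together at the high end of the series, joined by a 1.1-fold higher number from compound 2 to compound 3 (0.02 log units; within the scatter). The gap to the remaining compound is a 2.1-fold higher number from compound 1 to compound 3 (0.32 log units; beyond the scatter), a modest step.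

Next is compound 4 `COc1cc(Nc2ncnc3c(NC(=O)Nc4ccc(C(F)(F)F)cc4)cccc23)cc(OC)c1`. The change is 4-(trifluoromethyl)phenyl in place of 3,4-dichlorophenyl on an amide-type nitrogen.

All three measured steps exchange the substituted phenyl group at this same place. Besides the two above, there is a 2.0-fold higher number from compound 1 to compound 2 (0.30 log units; within the scatter). The largest of the three is therefore only modest, and two lie within the scatter. Going by the values given here, no measured compound carries 4-(trifluoromethyl)phenyl, so the data hold no direct test of this exchange. On that record, no step beyond the scatter is expected in this assay, and any shift is expected to be small and downward. The expected step is a 1.4-fold lower number from compound 3 to compound 4 (0.14 log units; within the scatter) in this estimate. For compound 4 the estimated value is 4500 nM, with an expected range from 2000 nM to 10000 nM as its limits.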

Compound 4, concentration for 50% growth inhibition: 3920 nM
Compound 4: the middle estimate sits 1.1-fold (0.06 log units) above what was measured; low and high end bracket the measured number.
By their numbers in this assay, from the lowest: compounds 1, 4, 2 and 3 (each within the scatter of the next, the first and the last beyond it).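

In this assay, a fourth phenyl pattern on the amide-type nitrogen, 4-(trifluoromethyl)phenyl, lands within the scatter of all three earlier compounds (a 1.6-fold lower number from compound 3 to compound 4 (0.20 log units; within the scatter); a 1.5-fold lower number from compound 2 to compound 4 (0.18 log units; within the scatter); a 1.3-fold higher number from compound 1 to compound 4 (0.12 log units; within the scatter)). Going by these compounds alone, this position has therefore now taken chlorine, methyl, fluorine and trifluoromethyl substituents, and the only step beyond the scatter is still the modest one (a 2.1-fold higher number from compound 1 to compound 3 (0.32 log units; beyond the scatter)), while compound 4 does not separate from either end of that gap. The change from 3,4-dichlorophenyl to 4-(trifluoromethyl)phenyl, which goes from 8 to 10 heavy atoms and swaps chlorine for fluorine, adds no clear step, and nothing available here accounts for the small differences that are seen.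

Still open, on these data alone, is whether a phenyl ring carrying a different kind of group on this nitrogen, such as a carboxylic acid, a dimethylamino group or a longer alkoxy chain, would give a step clearly beyond the scatter. Also open, as far as these compounds go, is how the growth-inhibition numbers respond to changes elsewhere on the shared core, which stays the same in all four compounds.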